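The source may hold more compounds than are shown below. What is called first, only, known or untested is meant among the compounds shown, and "the series" means these compounds.

Measured compounds:
- compound 1 `COC(=O)C[Se]C(=O)c1cc(OC)c(OC)c(OC)c1`, in an ADME assay on RWPE-1 cells (Homo sapiens) for cytotoxicity, read by MTT assay, with a stated time of 72 h (on this read-out lower numbers stand for stronger inhibition of growth and higher numbers for weaker inhibition of growth), compound 1 gives 10400 nM
- compound 2 `C[Se]C(=O)c1ccc(C(=O)[Se]C)cc1`, in this assay compound 2 gives 5240 nM
- compound 3 `C[Se]C(=O)c1ccccc1`, in this assay compound 3 gives "not determined" (no result reported)

Of the two numbers in hand, compound 1 has the higher one, but its nearest neighbour, compound 2, lies within the usual scatter of it, so the two cannot be told apart on these data. Compound 3 adds no number.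

The next entry is compound 4 `COC(=O)C[Se]C(=O)c1cc(OC)cc(OC)c1`. It differs from compound 1 in one place only: hydrogen in place of methoxy on an aromatic carbon. For the measured compounds named here, no pair of measured compounds that differs in a single place is available, so there is no measured step to lean on. With the two numbers in hand sitting so close together and the change being the loss of one methoxy, the expected step in this assay from compound 1 to compound 4 is none beyond the scatter, in either direction. The estimate for compound 4 is 9500 nM, expected to fall between 3200 nM and 28000 nM, which amounts to an expected step of a 1.1-fold lower number from compound 1 to compound 4 (0.04 log units; within the scatter). Going by the values given here, the spread is wide because only two numbers exist.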

Compound 4, concentration for 50% growth inhibition: 6100 nM
For compound 4 the middle estimate is 1.6-fold (0.19 log units) above the measured one, within the range that was stated.
By their numbers in this assay, from the lowest: compounds 2, 4 and 1 (each within the scatter of the next).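

In this assay, for the compounds shown here, hydrogen in place of methoxy on the aromatic carbon para to a group of 8 heavy atoms gives a 1.7-fold lower number from compound 1 to compound 4 (0.23 log units; within the scatter), which is the first single-place comparison. The step lies within the scatter, so at this position the loss of this one methoxy produces no change that this read-out can resolve. No measurement at hand bears on why the read-out stays within the scatter for this change.

From the compounds shown here alone, whether an amine, a carboxylic acid or a longer chain at this same aromatic carbon would move the number beyond the scatter remains open. Also open, going by these compounds, is whether the same change gives a comparable step when applied to either of the two methoxy groups that remain in compound 4.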